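The source may hold more compounds than are shown below. What is called first, only, known or untested is meant among the compounds shown, and "the series" means these compounds.

Measured so far:
- Compound 1, `O=C(NCc1ccc(CNS(=O)(=O)c2ccccc2)cc1)c1cccc(F)c1`: 100 nM
- Compound 2, `COc1ccccc1C(=O)NCc1ccc(CNS(=O)(=O)c2ccccc2)cc1`: 1 nM
- Compound 3, `O=C(NCc1ccc(CNS(=O)(=O)c2ccccc2)cc1)c1ccccc1F`: 1000 nM

All three were tested in an assay on MDA-MB-231 cells for binding affinity to C-X-C chemokine receptor type 4 (Homo sapiens), read by immunofluorescence and microscopy, with stated times of 10 min and 30 min; on this read-out lower numbers stand for an effect already at smaller amounts and higher numbers for an effect only at larger amounts of compound. Among the three numbers compound 3 stands highest: it is a 10-fold higher number from compound 1 to compound 3 (1.00 log units; beyond the scatter) away from compound 1, and a 1000-fold higher number from compound 2 to compound 3 (3.00 log units; beyond the scatter) from compound 2, so it is the weakest binder of the set.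

Compound 4, `Cc1ccccc1C(=O)NCc1ccc(CNS(=O)(=O)c2ccccc2)cc1`, has not yet been measured. It differs from compound 3 in one place: methyl in place of fluoro on an aromatic carbon. The methyl enters on an aromatic carbon of a six-membered aromatic ring of carbon only, ortho to a large group.

Among the measured compounds shown here, two measured steps bear on this. The step of a 1000-fold higher number from compound 2 to compound 3 (3.00 log units; beyond the scatter) shows that what sits at this aromatic carbon matters greatly: exchanging the methoxy for a fluoro raised the number enormously. The step of a 10-fold higher number from compound 1 to compound 3 (1.00 log units; beyond the scatter) shows that a fluoro at this place is worse than the same fluoro one carbon further round the ring. A methyl is neither a fluoro nor a methoxy, so a step in the direction of compound 2 is expected, but a smaller one. Compound 4 is therefore estimated at 30 nM, with a range from 3 nM to 300 nM, which means an expected step of a 33-fold lower number from compound 3 to compound 4 (1.52 log units; beyond the scatter).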

Compound 4, effective concentration (reported as EC, without a stated level of effect): 1 nM
Estimate against measurement, compound 4: 30-fold (1.48 log units) above, outside the stated range (below it).
By their numbers in this assay, from the lowest: compounds 2 and 4 (each within the scatter of the next); then compound 1; then compound 3.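

Putting a methyl where compound 3 has a fluoro gives a 1000-fold lower number from compound 3 to compound 4 (3.00 log units; beyond the scatter), and the 2-methylphenyl group also compares well with the 3-fluorophenyl group, with a 100-fold lower number from compound 1 to compound 4 (2.00 log units; beyond the scatter), so the exchange of a single heavy atom at this aromatic carbon can span the full range of numbers in the set. Exchanging the methoxy for a methyl gives no change at the digits printed from compound 2 to compound 4 (within the scatter), so the oxygen of the methoxy is not required for a number this low, and a fluoro at this place is what stands apart from the other two groups. No measurement is available that would explain why the methyl and methoxy match each other while the fluoro differs so sharply from both.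

The compounds shown cover only fluoro, methyl and methoxy at this aromatic carbon, so it remains open whether a chloro, an ethyl or an amine here would keep the low number or lose it. On these data alone, it is also open how a 3-methylphenyl group would compare with the 2-methylphenyl group, given that moving the fluoro one carbon round the ring changed the number.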